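Trimming the Amide to an Amine: Cytotoxicity Outlook

The source may report more compounds than this note shows. Statements on the series, on what has been measured and on what is new or still open speak of the compounds shown alone.

Compound 1 `COc1ccc(CNC(=O)c2cc3cc(OC)c(OCCCOc4no[n+]([O-])c4S(=O)(=O)c4ccccc4)cc3oc2=O)cc1`: 5950 nM
Compound 2 `COc1ccc(NC(=O)c2cc3cc(OC)c(OCCCOc4no[n+]([O-])c4S(=O)(=O)c4ccccc4)cc3oc2=O)cc1`: 5470 nM

In an ADME assay on MCF-10A cells (Homo sapiens) for cytotoxicity, read by MTT assay, with a stated time of 48 h (a higher number here means a weaker inhibitor, a lower number a stronger inhibitor), compound 2 gives 5470 nM, and compound 1 gives 5950 nM; the step of a 1.1-fold lower number from compound 1 to compound 2 (0.04 log units; within the scatter) places the two within the scatter of each other, so neither can be ranked above the other. Compound 3 `COc1cc2cc(N)c(=O)oc2cc1OCCCOc1no[n+]([O-])c1S(=O)(=O)c1ccccc1` differs from compound 2 by amino in place of (4-methoxyphenyl)carbamoyl on an aromatic carbon. For the measured compounds named here, no measured step bears on this change, since the only step in hand, a 1.1-fold lower number from compound 1 to compound 2 (0.04 log units; within the scatter), varies the amide substituent without removing the carbamoyl. With no guide, compound 3 is expected to stay near compound 2, with an estimated step of a 1.5-fold higher number from compound 2 to compound 3 (0.17 log units; within the scatter), giving an expected value of 8000 nM within 3000 nM to 25000 nM.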

Compound 3, half-maximal inhibitory concentration: 6450 nM
Compound 3: middle estimate off by 1.2-fold (0.09 log units), on the high side, and the stated range covers the measured number.
By their numbers in this assay, from the lowest: compounds 2, 1 and 3 (each within the scatter of the next).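

In this assay, amino in place of (4-methoxyphenyl)carbamoyl gives a 1.2-fold higher number from compound 2 to compound 3 (0.07 log units; within the scatter) and amino in place of (4-methoxybenzyl)carbamoyl gives a 1.1-fold higher number from compound 1 to compound 3 (0.04 log units; within the scatter) on the same aromatic carbon. Across these three compounds, then, the full carbamoyl arm with its six-membered aromatic ring can give way to amino, a single nitrogen, without any step leaving the scatter. Nothing measured here accounts for this result. From the compounds shown here alone, whether a carboxylic acid, an unsubstituted carboxamide or an acetylated amine at this position would stay in the same range remains open.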